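The compounds below may be only part of what the source reports. "The series", "measured", "known", "first", "only" and "open" are said of these compounds alone.

Compound 1 `CN1CCN(c2nc(-c3ccc(Cl)c(Cl)c3)nc3[nH]cnc23)CC1` was examined in an assay on cells for displacement of a labelled ligand from adenosine receptor A1 (Homo sapiens), read by scintillation counting and radioligand binding, with a stated time of 60 min (on this read-out lower numbers stand for stronger inhibition and higher numbers for weaker inhibition), where compound 1 gives 631 nM. Compound 2 `CN1CCN(c2nc(-c3ccccc3O)nc3c2ncn3C)CC1` was run alongside it, and in this assay compound 2 gives 631 nM; the two values are level at the digits reported, which places compound 1 alongside compound 2 within the usual scatter of this kind of measurement. Among the compounds with values here, the two compounds differ in more than one place, so no single step between them can be drawn out.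

Compound 3 `CN1CCN(c2nc(-c3cc(Cl)ccc3Cl)nc3[nH]cnc23)CC1` has not yet been measured. It is related to compound 1 by one change: 2,5-dichlorophenyl in place of 3,4-dichlorophenyl on an aromatic carbon. Within the data shown here, no measured pair in this set isolates such a rearrangement, so the direction of the step is not anchored by data. Compound 3 is expected to land close to compound 1, with a step of a 1.6-fold higher number from compound 1 to compound 3 (0.20 log units; within the scatter), most likely within the scatter or a modest weakening. On that basis compound 3 is estimated at 1000 nM, within a range from 300 nM to 3500 nM.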

Compound 3, inhibition constant: 2510 nM
Beside the measured number, compound 3's estimate is 2.5-fold (0.40 log units) below it, and the stated range covers the measured number.
By their numbers in this assay, from the lowest: compounds 1 and 2 (each within the scatter of the next); then compound 3.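

Rearranging the two chlorines, with the atoms and the counts of the group unchanged, is not neutral at this position: in this assay, 2,5-dichlorophenyl in place of 3,4-dichlorophenyl gives a 4.0-fold higher number from compound 1 to compound 3 (0.60 log units; beyond the scatter). The earlier compounds shown here could not show this, since compound 1 and compound 2 differ in more than one place, whereas this pair shows that the chlorine arrangement alone on the phenyl group can shift the number beyond the scatter. Nothing available here bears on the reason for this step.

The compounds shown leave open which chlorine placement accounts for the step, and how an unsubstituted phenyl, a 4-chlorophenyl or a 3,4-difluorophenyl group would read at this position. They also leave open whether the same rearrangement would give a similar step with the methyl group that compound 2 carries on the core.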